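Two limit-bound hydrazones and an untested bromophenyl relative

The source may report more compounds than this note shows. Statements on the series, on what has been measured and on what is new or still open speak of the compounds shown alone.

Measured compounds:
Compound 1, `COc1ccccc1NC(=S)N/N=C/c1ccc2ccccc2n1`: > 100000 nM
Compound 2, `Cc1ccc(NC(=O)N/N=C/c2ccc3ccccc3n2)cc1`: > 100000 nM

In a functional assay on HeLa cells (Homo sapiens) for antiproliferative activity, read by sulforhodamine B assay, with a stated time of 72 h (a lower number here means a stronger inhibitor, a higher number a weaker inhibitor), compound 1 gives > 100000 nM, which is a limit of the assay and not a number. Compound 2, in this assay, likewise gives > 100000 nM, again a limit rather than a measured figure. Within the data shown here, compound 1 therefore stands at the limit, (the limit of > 100000 nM in this assay, at which 2 of the 2 values shown sit), and with both measured compounds resting there no step between them can be stated. The untested compound 3, `S=C(N/N=C/c1ccc2ccccc2n1)Nc1ccc(Br)cc1`, differs from compound 1 by 4-bromophenyl in place of 2-methoxyphenyl on an amide-type nitrogen. Since the two measured values both sit at the limit, nothing in the data shows that the group on this nitrogen moves the read-out at all, and the expected step of a number no higher from compound 1 to compound 3 (the limit leaves the size open) is none beyond the usual scatter. Compound 3 is thus expected to give about 100000 nM in this assay, with a plausible range from 20000 nM to 500000 nM, and most likely it will again be reported only as a limit.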

Compound 3, half-maximal inhibitory concentration: 56800 nM
The estimate for compound 3 lay 1.8-fold (0.25 log units) above the measured number; the range from low to high includes it.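

In this assay compound 3 gives 56800 nM, the first figure in this set that is a number and not a limit, so the group on this amide-type nitrogen, whose other neighbour is the thiocarbonyl carbon, can be tied to a read-out inside the range of the assay. The change of 2-methoxyphenyl to 4-bromophenyl amounts to an at least 1.7-fold lower number from compound 1 to compound 3 (0.24 log units; that floor lies within the scatter), and since this is only a floor, it neither establishes a real change nor fixes how large one might be. Compound 1, the starting point of that step, remains a limit and not a number, as do most of the values shown: the limit of > 100000 nM in this assay, at which 2 of the 3 values shown sit.

The compounds shown leave open whether the bromine, the loss of the methoxy group or the different placement on the phenyl ring accounts for the number seen with compound 3. They also leave open whether chlorine, an amine or a carboxylic acid on that phenyl ring would give a measurable value, and what a carbonyl in place of the thiocarbonyl would do with the 4-bromophenyl group held fixed.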